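Swapping Trifluoromethyl for Acetamido on a Methoxy Biphenyl

A few compounds are considered here, and "the series" means these few. Any claim that something is new, unique, unknown or untested is made for them only; others in the source may bear on it.

Compound 1 `C=CCc1cc(-c2ccc(C(F)(F)F)cc2)ccc1O`: 74000 nM
Compound 2 `C=CCc1cc(-c2ccccc2C(F)(F)F)ccc1O`: 82000 nM
Compound 3 `C=CCc1cc(-c2ccc(C(F)(F)F)cc2)ccc1OC`: limit > 100000 nM

All three were tested in a functional assay on HUVEC cells (Homo sapiens) for antiproliferative activity, read by MTT assay, with a stated time of 24 h; a higher number here means a weaker inhibitor, a lower number a stronger inhibitor. Compound 1 and compound 2 give numbers that lie within the usual scatter of each other. From the compounds shown here alone, for compound 3 the assay reports only a limit, > 100000 nM, so its true position is unknown beyond that (the limit of > 100000 nM in this assay, at which 1 of the 3 values shown sits). Within the data shown here, the single measured step, an at least 1.3-fold higher number from compound 1 to compound 3 (0.13 log units; that floor lies within the scatter), concerns the oxygen, not the group that changes next.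

Compound 4 `C=CCc1cc(-c2ccc(NC(C)=O)cc2)ccc1OC` differs from compound 3 by acetamido in place of trifluoromethyl on an aromatic carbon. Among the measured compounds shown here, no measured pair shows this exchange, so the data give no direction for it. Compound 4 is therefore expected near the same level, estimated at 120000 nM (range 40000 nM to 400000 nM), a step that the limit leaves unreadable from compound 3 to compound 4.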

Compound 4, half-maximal inhibitory concentration: > 100000 nM
Compound 4 was reported as a limit; the forecaster's own chance of this, stated with the estimate: 60%; the middle value is on the limit's open side.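

Compound 3 and compound 4 are both reported only as a limit, so no step between them can be read: the limit of > 100000 nM in this assay, at which 2 of the 4 values shown sit.

The compounds shown leave open whether acetamido in place of trifluoromethyl changes the activity at all, and in which direction.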